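The compounds below may be only part of what the source reports. "The series", "measured", "known", "first", "only" and "open" are said of these compounds alone.

The series shares one core, seen in compound 1 `CC(C)(C)OC(=O)Nc1ccc(NC(=O)CCc2cccc3c2B(O)OC3)cc1`, compound 2 `O=C(CCc1cccc2c1B(O)OC2)Nc1cccc2ccccc12` and compound 3 `O=C(CCc1cccc2c1B(O)OC2)Nc1cccc(-c2ccc(F)cc2)c1`, with only the amide-bound aryl group changing. In a functional assay on SK-OV-3 cells (Homo sapiens) for antiproliferative activity, read by MTT assay, with a stated time of 72 h (a higher number here means a weaker inhibitor, a lower number a stronger inhibitor), compound 1 reaches only the limit of > 100000 nM. In this assay compound 2 gives 170 nM, and compound 3 gives 93 nM, the two numbers lying within the usual scatter of each other, so neither can be set apart. Compound 4 `CC(=O)c1cccc(-c2cccc(NC(=O)CCc3cccc4c3B(O)OC4)c2)c1` differs from compound 3 in one place (3-acetylphenyl in place of 4-fluorophenyl on an aromatic carbon). Since no comparable exchange has been measured in this assay, compound 4 is expected to stay close to compound 3, with a step from compound 3 to compound 4 of a 1.6-fold higher number from compound 3 to compound 4 (0.21 log units; within the scatter), which would not exceed the scatter. Compound 4 is therefore estimated at 150 nM, between 40 nM and 600 nM.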

Compound 4, half-maximal inhibitory concentration: 68 nM
Compound 4: the middle estimate sits 2.2-fold (0.34 log units) above what was measured; measured number inside the range.
By their numbers in this assay, from the lowest: compounds 4, 3 and 2 (each within the scatter of the next, the first and the last beyond it). At a limit, above all of these: compound 1.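

In this assay, exchanging 4-fluorophenyl for 3-acetylphenyl gives a 1.4-fold lower number from compound 3 to compound 4 (0.14 log units; within the scatter). This position, on an aromatic carbon and meta to a large group, therefore carries 3-acetylphenyl, with 9 heavy atoms and 1 hydrogen-bond acceptor, with no step beyond the scatter from 4-fluorophenyl, with 7 heavy atoms and 0 hydrogen-bond acceptors. Nothing given here bears on a cause for this step. From the compounds shown here alone, what an amine or a carboxylic acid in place of the acetyl group would give in this assay stays open, and so does whether any such group would move the number beyond the scatter.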